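Replacing the quaternary hydrazide in compound 2 with a trimethylammonium chain

The source may hold more compounds than are shown below. What is called first, only, known or untested is meant among the compounds shown, and "the series" means these compounds.

Of the compounds shown here, two have been measured in a functional assay (brain) for inhibition, with Rattus norvegicus as the target; a lower number here means a stronger inhibitor, a higher number a weaker inhibitor. Compound 1 `Cc1c(C)c2c(c(C)c1O)CC[C@@](C)(CC[N+](C)(C)C)O2` gives 2300 nM. Compound 2 `Cc1c(C)c2c(c(C)c1O)CCC(C)(C(=O)[N-][N+](C)(C)C)O2` gives 14000 nM, the higher of the two numbers, and its distance from compound 1 lies beyond the scatter, so compound 2 is the weaker inhibitor of the pair.

Compound 3 `Cc1c(C)c2c(c(C)c1O)CCC(C)(CC[N+](C)(C)C)O2` has not yet been measured. It differs from compound 2 by the change (a group of 6 heavy atoms (5 carbon, 1 nitrogen; no ring) in place of a group of 7 heavy atoms (4 carbon, 2 nitrogen, 1 oxygen; no ring), on a saturated ring carbon). With that change compound 3 takes the same chain that compound 1 carries on the same ring carbon, and it differs from compound 1 only in that the configuration at that ring carbon is left unspecified.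

Among the compounds with values here, no measured step is available for this change, so the expectation rests on the resemblance to compound 1. Because compound 1 gives 2300 nM in this assay, compound 3 is expected to give a lower number than compound 2, with a step of a 4.7-fold lower number from compound 2 to compound 3 (0.67 log units; beyond the scatter) that should exceed the scatter. The estimate for compound 3 is 3000 nM, with a likely range from 1200 nM to 8000 nM.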

Compound 3, half-maximal inhibitory concentration: 2600 nM
Estimate against measurement, compound 3: 1.2-fold (0.06 log units) above; the range from low to high includes it.
By their numbers in this assay, from the lowest: compounds 1 and 3 (each within the scatter of the next); then compound 2.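

In this assay, putting the trimethylammonium chain in place of the quaternary hydrazide, on a saturated ring carbon next to the ring oxygen, gives a 5.4-fold lower number from compound 2 to compound 3 (0.73 log units; beyond the scatter). Within the data shown here, this is the first measured step at this position, and it shows that, on the shared core, the group with net charge +1 goes with the lower number and the group with no net charge and a carbonyl goes with the higher one. Set against compound 1, compound 3 gives a 1.1-fold higher number from compound 1 to compound 3 (0.05 log units; within the scatter), so the two numbers cannot be told apart, and the only structural difference behind that comparison is this: the fact that one of compounds 1 and 3 is drawn with a defined configuration and the other without, at the place where they differ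

The whole group changes in the step from compound 2, so the compounds shown do not separate the part played by the carbonyl, the extra nitrogen or the net charge, and the form with the opposite configuration at this ring carbon remains unread. They also leave open whether a longer chain ending in the same trimethylammonium, or a dimethylamine or a carboxylic acid at the end of the chain, would keep the number of compound 3 in this assay.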